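The source may report more compounds than this note shows. Statements on the series, on what has been measured and on what is new or still open speak of the compounds shown alone.

Measured so far in a functional assay on DU-145 cells (Homo sapiens) for antiproliferative activity, read by MTT assay, with a stated time of 72 h; a higher number here means a weaker inhibitor, a lower number a stronger inhibitor:
- Compound 1 `CCN(CC)CCCOc1cc2ncnc(Nc3ccc(C#N)cc3)c2cc1OC`: 68900 nM
- Compound 2 `COc1cc2c(Nc3ccc(C#N)cc3)ncnc2cc1OCCCN1CCC(C)CC1`: 16600 nM
- Compound 3 `COc1cc2c(Nc3ccc(C#N)cc3)ncnc2cc1OCCCN1CCC(c2ccccc2)CC1`: 6790 nM

In this assay compound 2 gives 16600 nM, the middle of the three numbers, with compound 3 lower and compound 1 higher. The next compound to consider is compound 4 `COc1cc2c(Nc3ccccc3C#N)ncnc2cc1OCCCN1CCC(C)CC1`, which has the same atoms as compound 2, joined differently: 2-cyanophenyl stands in place of 4-cyanophenyl on a nitrogen on an aromatic ring (2-cyanophenyl in place of 4-cyanophenyl on a nitrogen on an aromatic ring).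

The measured steps all concern the other end of the molecule, the amine group on the saturated chain. Replacing diethylamino with 4-methylpiperidin-1-yl gives a 4.2-fold lower number from compound 1 to compound 2 (0.62 log units; beyond the scatter). Replacing it with 4-phenylpiperidin-1-yl gives a 10-fold lower number from compound 1 to compound 3 (1.01 log units; beyond the scatter). Phenyl in place of methyl on a saturated ring carbon gives a 2.4-fold lower number from compound 2 to compound 3 (0.39 log units; beyond the scatter).

None of these steps moves the nitrile, so they cannot give a direction for this change. They show only how far the numbers have moved in this small set when one part is altered. With no evidence for either direction, the expected result is no step beyond the scatter, and the estimate is a 1.2-fold higher number from compound 2 to compound 4 (0.08 log units; within the scatter). For compound 4 the expected value is 20000 nM, with an estimated range from 6500 nM to 60000 nM.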

Compound 4, half-maximal inhibitory concentration: 11900 nM
Compound 4: middle estimate off by 1.7-fold (0.23 log units), on the high side, within the range that was stated.
By their numbers in this assay, from the lowest: compounds 3, 4 and 2 (each within the scatter of the next, the first and the last beyond it); then compound 1.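

Moving the nitrile from 4-cyanophenyl to 2-cyanophenyl on the nitrogen gives a 1.4-fold lower number from compound 2 to compound 4 (0.14 log units; within the scatter) in this assay. Within the data shown here, this is the first measured change at this end of the molecule, and it shows that, with the 4-methylpiperidin-1-yl group held fixed, this assay does not separate the two arrangements of the same atoms. By contrast, all three steps at the amine end lie beyond the scatter, even the smallest, a 2.4-fold lower number from compound 2 to compound 3 (0.39 log units; beyond the scatter), so in this small set the amine group is the only place where a change has clearly moved the number, and nothing shown accounts for the lack of a clear shift at the nitrile.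

This single pair cannot say whether 2-cyanophenyl and 4-cyanophenyl would also read alike with diethylamino or 4-phenylpiperidin-1-yl at the end of the chain, as in compound 1 and compound 3. It also leaves open whether the nitrile matters at all, a question that a compound carrying a carboxylic acid or a chlorine atom in its place on the same ring could begin to answer.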